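This account rests on a few compounds, and the source may have more. Where it says the series, first, only, none or still open, it means among the compounds named here.

In an ADME assay on HeLa cells (Homo sapiens) for cytotoxicity, read by ATP content, with a stated time of 3 days (a higher number here means that more compound is tolerated, a lower number that less compound is tolerated), compound 1 `Cn1ccc(-n2c(=O)n(Cc3cc4cc(Cl)ccc4n3CCCC#N)c3cnccc32)n1` gives > 50000 nM, which is a limit of the measurement rather than a number. Compound 2 `CC(C)CCn1c(Cn2c(=O)n(C3CC3)c3ccncc32)nc2ncccc21` also stops at a limit, > 100000 nM. Compound 3 `O=c1n(Cc2nc3cnccc3n2CCCCO)c2cnccc2n1C1CC1` likewise ends at a limit, > 100000 nM. So compound 1 stands where all values shown stand, at a limit, the only results seen being the limit of > 100000 nM in this assay, at which 2 of the 3 values shown sit, and (the limit of > 50000 nM in this assay, at which 1 of the 3 values shown sits). Compound 4 `CS(=O)(=O)c1ccc(-n2c(=O)n(Cc3cc4cc(Cl)ccc4n3CCCC#N)c3cnccc32)cc1` differs from compound 1 by one change, (4-(methylsulfonyl)phenyl in place of 1-methyl-1H-pyrazol-3-yl on an aromatic nitrogen), that is, 4-(methylsulfonyl)phenyl in place of 1-methyl-1H-pyrazol-3-yl on an aromatic nitrogen. Going by the values given here, no measured pair differing in one place exists here, so no step size can be read from data. The expected step of a number no higher from compound 1 to compound 4 (the limit leaves the size open) is none beyond the usual scatter. For compound 4 the estimate is 50000 nM, expected between 20000 nM and 100000 nM, most likely reported again as a limit.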

Compound 4, half-maximal cytotoxic concentration: > 50000 nM
Compound 4 ended at the assay's limit; the forecaster's own chance of this, stated with the estimate: 80%; the middle value lies on the limit itself.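

Compound 1 and compound 4 both end at a limit rather than a number, so no step between them can be read: the limit of > 50000 nM in this assay, at which 2 of the 4 values shown sit.

The compounds shown leave open what concentration, if any, would harm these cells.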